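Plasma Half-Life: Benzyl in Place of Cyclopentyl

A few compounds are considered here, and "the series" means these few. Any claim that something is new, unique, unknown or untested is made for them only; others in the source may bear on it.

Of the compounds shown here, three sharing one core have been tested in an in vitro ADME assay on a cell-free system (plasma) for pharmacokinetics; on this read-out higher numbers stand for a longer-lived compound and lower numbers for a shorter-lived compound. Compound 1 `C=CCN(CCCC(=O)OCC)C(=O)/C(C)=C/c1ccc(C(=O)Oc2ccc(C(=N)N)cc2)cc1` gives < 0.0167 h, a limit of the assay rather than a number; this is the limit of < 0.0167 h in this assay, at which 1 of the 3 values shown sits. Compound 2 `CCOC(=O)C(C(=O)OCC)N(CCCC(=O)O)C(=O)/C(C)=C/c1ccc(C(=O)Oc2ccc(C(=N)N)cc2)cc1` gives 0.483 h in this assay. Compound 3 `C/C(=C\c1ccc(C(=O)Oc2ccc(C(=N)N)cc2)cc1)C(=O)N(CC(=O)O)C1CCCC1` gives 0.383 h, a number that lies within the usual scatter of that of compound 2, so the two cannot be told apart.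

Compound 4 `C/C(=C\c1ccc(C(=O)Oc2ccc(C(=N)N)cc2)cc1)C(=O)N(CC(=O)O)Cc1ccccc1` has not been measured. It differs from compound 3 by benzyl in place of cyclopentyl on an amide-type nitrogen. Among the compounds with values here, no measured pair shows the effect of such an exchange, so the step is expected to stay within the scatter: a 1.1-fold lower number from compound 3 to compound 4 (0.04 log units; within the scatter) is the estimate. For compound 4 the half-life is expected near 0.35 h, with a range from 0.12 h to 1 h.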

Compound 4, half-life: > 1 h
Compound 4 gave a limit, no number (the forecaster's own chance of this, stated with the estimate: 5%); middle value at least 2.8-fold (0.45 log units) from the limit.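

On the amide-type nitrogen, the choice of group matters: in this assay, benzyl in place of cyclopentyl gives an at least 2.6-fold higher number from compound 3 to compound 4 (0.41 log units; beyond the scatter). This is the only one-place change shown, and it establishes that this position alone can move the half-life beyond the usual scatter. Compound 4 gives a limit, not a number, so the full size of the step cannot be read: the limit of > 1 h in this assay, at which 1 of the 4 values shown sits.

The compounds shown leave open whether the aromatic ring or its one-carbon link carries the change. A cyclohexyl or phenethyl group on the same nitrogen would help separate the two.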